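Chain Methylation in Anilide Acyltransferase Inhibitors

The source may hold more compounds than are shown below. What is called first, only, known or untested is meant among the compounds shown, and "the series" means these compounds.

Compound 1 `CCCCCCCC/C=C/CCCCCCCC(=O)Nc1ccccc1CC` and compound 2 `CCCCCCCC/C=C/CCCCCCCC(=O)Nc1ccccc1C(C)C` share one core, compound 3 `CCCCCCCC(C)(C)C(=O)Nc1c(OC)cc(OC)cc1OC` another; the difference between the two cores is not broken down here. In an assay on microsomes from intestine for inhibition of acyl-CoA:cholesterol acyltransferase (Oryctolagus cuniculus) (on this read-out higher numbers stand for weaker inhibition and lower numbers for stronger inhibition), compound 1 gives 1200 nM and compound 2 gives 600 nM. In this assay compound 3 gives 180 nM, the lowest of the three numbers, its steps to both others beyond the scatter. The change methyl in place of hydrogen on a saturated chain carbon bound to an aromatic carbon and a saturated chain carbon gave a 2.0-fold lower number from compound 1 to compound 2 (0.30 log units; within the scatter). Compound 4 `CCCCCCCCC(C)(C)C(=O)Nc1c(OC)cc(OC)cc1OC` carries the same kind of change, methyl in place of hydrogen on a saturated chain carbon, eight bonds along the chain from a carbonyl carbon: methyl again replaces hydrogen, but here on a saturated chain carbon eight bonds along the chain from a carbonyl carbon rather than on one bound to an aromatic carbon and a saturated chain carbon. Within the data shown here, the step to compound 4 is expected at a 1.5-fold lower number from compound 3 to compound 4 (0.18 log units; within the scatter), a modest lowering resting on a 2.0-fold lower number from compound 1 to compound 2 (0.30 log units; within the scatter), since the only measured precedent of this kind is compound 1 with 1200 nM against compound 2. Compound 4 is expected at 120 nM, between 50 nM and 300 nM.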

Compound 4, half-maximal inhibitory concentration: 59 nM
Compound 4: the middle estimate sits 2.0-fold (0.31 log units) above what was measured; measured number inside the range.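

In this assay, methyl in place of hydrogen on a saturated chain carbon, eight bonds along the chain from a carbonyl carbon, gave a 3.1-fold lower number from compound 3 to compound 4 (0.48 log units; beyond the scatter). Set beside the earlier step, the two sizes do not differ measurably: the same change on two cores in this assay, a 2.0-fold lower number (0.30 log units; within the scatter) from compound 1 to compound 2 and a 3.1-fold lower number (0.48 log units; beyond the scatter) from compound 3 to compound 4, 1.5-fold (0.18 log units) apart, within the scatter of two such steps. Among these compounds, this is only one pair per core, with the methyl at a different place in each, so it supports carrying the change between these two cores but gives no general rule for the series.

Open, going by these compounds, is whether a longer chain at the same place, in the core of compound 4, lowers the number further. Also open, on these data alone, is how an amine or a carboxylic acid on that chain would read.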